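A few compounds are considered here, and "the series" means these few. Any claim that something is new, unique, unknown or untested is made for them only; others in the source may bear on it.

Measured so far in an assay on isolated protein (blood) for inhibition of Polyunsaturated fatty acid 5-lipoxygenase (Homo sapiens), read by ELISA, with stated times of 15 min and 30 min; on this read-out higher numbers stand for weaker inhibition and lower numbers for stronger inhibition:

- compound 1, `O=C(Oc1ccc(-c2ccccc2)cc1)c1cc([N+](=O)[O-])cc([N+](=O)[O-])c1`: > 50000 nM
- compound 2, `COc1ccc(NC(=O)c2cc([N+](=O)[O-])cc([N+](=O)[O-])c2)cc1`: 2700 nM

Compound 1 is the biphenyl ester of the shared dinitrobenzoyl unit. In this assay compound 1 sits at the limit of > 50000 nM in this assay, at which 1 of the 2 values shown sits; this is a limit of the assay and not a number. Among the compounds with values here, compound 2 carries the same dinitrobenzoyl unit as an anilide with a methoxy on the aniline ring, and in this assay compound 2 gives 2700 nM, the only number so far. Within the data shown here, no step between measured compounds is available, so the size of the change from an anilide hydrogen to a further methoxy cannot be read from data here.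

Compound 3, `COc1ccc(NC(=O)c2cc([N+](=O)[O-])cc([N+](=O)[O-])c2)cc1OC`, differs from compound 2 by methoxy in place of hydrogen on an aromatic carbon. Among the measured compounds shown here, with no measured step to rest on, the expected change from compound 2 to compound 3 is none beyond the usual scatter, in either direction. Compound 3 is therefore estimated at 3000 nM, with a range from 1000 nM to 10000 nM. The expected step of a 1.1-fold higher number from compound 2 to compound 3 (0.05 log units; within the scatter) is accordingly held within the scatter.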

Compound 3, half-maximal inhibitory concentration: > 50000 nM
Compound 3 was reported as a limit; the forecaster's own chance of this, stated with the estimate: 15%; at least 16-fold (1.22 log units) between middle value and limit.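

In this assay, a methoxy in place of hydrogen, ortho to a methoxy group and meta to a large group, is far from a neutral change: an at least 18-fold higher number from compound 2 to compound 3 (1.26 log units; beyond the scatter). Compound 3 gives > 50000 nM, which is a limit of the assay and not a number, so the step gives only a minimum size for the change. This position on the aromatic ring is therefore sensitive to a substituent of only 2 heavy atoms, and compound 2 remains the only compound in the series with a number: the limit of > 50000 nM in this assay, at which 2 of the 3 values shown sit.

One substitution cannot show whether the step belongs to methoxy specifically or to any group at this position, and a fluorine, a hydroxyl or an amine placed there would separate those readings. The compounds shown also leave open what the methoxy of compound 2 itself contributes in this assay, a question that a hydroxyl or an ethoxy in its place would address.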